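A few compounds are considered here, and "the series" means these few. Any claim that something is new, unique, unknown or untested is made for them only; others in the source may bear on it.

For the measured compounds named here, in a functional assay on MOLT-4 cells (Homo sapiens) for inhibition, read by MTT assay, with a stated time of 72 h (a higher number here means a weaker inhibitor, a lower number a stronger inhibitor), compound 2 (`COc1cc(NC(C)CCCNC(=O)NNC(=O)Nc2ccc(Cl)cc2)c2ncccc2c1`) gives 186000 nM, the highest number of the three measured so far. Compound 1 (`COc1cc(NC(C)CCCNC(=O)Nc2cccc(F)c2)c2ncccc2c1`) gives 23000 nM and compound 3 (`COc1cc(NC(C)CCCNC(=O)Nc2cc(C(F)(F)F)cc(C(F)(F)F)c2)c2ncccc2c1`) gives 12000 nM, two values within the scatter of each other. Compound 4 (`COc1cc(NC(C)CCCNC(=O)Nc2cccc(C(F)(F)F)c2)c2ncccc2c1`) is not yet measured and differs from compound 2 in one place: 3-(trifluoromethyl)phenyl in place of ((4-chlorophenyl)carbamoyl)amino on an amide-type nitrogen. Here 3-(trifluoromethyl)phenyl stands in place of ((4-chlorophenyl)carbamoyl)amino on an amide-type nitrogen.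

Going by the values given here, the one measured step that bears on this change is an 8.1-fold higher number from compound 1 to compound 2 (0.91 log units; beyond the scatter), which brings in the same ((4-chlorophenyl)carbamoyl)amino group that compound 4 lacks. Compound 4 reverses that kind of change, so a step of similar size is expected in the opposite direction, towards a lower number. Compound 1 and compound 3 both carry a substituted phenyl at this place, and neither goes against that expectation.

For compound 4 the estimated value is 17000 nM, with an expected range of 8000 nM to 36000 nM. This estimate corresponds to an expected 11-fold lower number from compound 2 to compound 4 (1.04 log units; beyond the scatter).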

Compound 4, half-maximal inhibitory concentration: 20000 nM
Beside the measured number, compound 4's estimate is 1.2-fold (0.07 log units) below it; measured number inside the range.
By their numbers in this assay, from the lowest: compounds 3, 4 and 1 (each within the scatter of the next); then compound 2.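

In this assay, a second aryl urea now shows the same separation at the amide-type nitrogen: with 3-(trifluoromethyl)phenyl in place of ((4-chlorophenyl)carbamoyl)amino there is a 9.3-fold lower number from compound 2 to compound 4 (0.97 log units; beyond the scatter), so the high number of compound 2 no longer rests on the comparison with compound 1 alone. Changes on the phenyl ring itself do not separate the compounds: trifluoromethyl in place of fluoro gives a 1.2-fold lower number from compound 1 to compound 4 (0.06 log units; within the scatter), and hydrogen in place of trifluoromethyl gives a 1.7-fold higher number from compound 3 to compound 4 (0.22 log units; within the scatter). Among the compounds shown, only compound 2 stands apart from the directly attached substituted phenyl groups.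

The compounds shown do not separate the extra carbamoylamino unit from the 4-chloro substituent, and they leave open how a pyridine ring, an aminophenyl group or a plain alkyl chain would behave at this nitrogen. No measurement shown accounts for the step from compound 2 to compound 4.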